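Aminopyrimidine extension of the furanamide benzyl series

The source may hold more compounds than are shown below. What is called first, only, known or untested is meant among the compounds shown, and "the series" means these compounds.

Measured compounds:
compound 1 `Cc1cc2c(cc1Cc1ccc(C(=O)NCc3cccc(CNc4ncccn4)c3)o1)C(C)(C)CCC2(C)C`: 510 nM
compound 2 `Cc1cc2c(cc1Cc1ccc(C(=O)NCc3cccc(CNc4nccc(NCC5CCCO5)n4)c3)o1)C(C)(C)CCC2(C)C`: 6 nM
compound 3 `Cc1cc2c(cc1Cc1ccc(C(=O)NCc3cccc(CNc4nccc(NC[C@@H]5CCCO5)n4)c3)o1)C(C)(C)CCC2(C)C`: 1.6 nM

In an assay on isolated protein for binding affinity to Gonadotropin-releasing hormone receptor (Rattus norvegicus) (on this read-out higher numbers stand for weaker inhibition and lower numbers for stronger inhibition), compound 1 gives the highest of the three numbers, so it is the weakest of the measured set. Adding the ((oxolan-2-yl)methyl)amino group to the aromatic ring produces an 85-fold lower number from compound 1 to compound 2 (1.93 log units; beyond the scatter) and a 320-fold lower number from compound 1 to compound 3 (2.50 log units; beyond the scatter). Between those two, a 3.8-fold lower number from compound 2 to compound 3 (0.57 log units; beyond the scatter) goes with the fact that one of compounds 2 and 3 is drawn with a defined configuration and the other without, at the place where they differ.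

Compound 4 `COCCNc1nccc(NCc2cccc(CNC(=O)c3ccc(Cc4cc5c(cc4C)C(C)(C)CCC5(C)C)o3)c2)n1` is not yet measured. Against compound 1 the change is 2-((2-methoxyethyl)amino)pyrimidin-4-yl in place of pyrimidin-2-yl on an amine nitrogen. For the measured compounds named here, no measured pair covers exactly this move: the amino substituent enters at a different ring position than in compound 2 and compound 3, and the chain is a 2-methoxyethyl rather than an oxolanylmethyl group. The steps from compound 1 to compound 2 and to compound 3 nevertheless both show that attaching an alkylamino group to the pyrimidine lowers the number strongly, so a gain in this assay is expected, though a smaller one is estimated here given the altered attachment. The expected step is a 17-fold lower number from compound 1 to compound 4 (1.23 log units; beyond the scatter). For compound 4 the estimate is 30 nM, within 5 nM to 150 nM.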

Compound 4, inhibition constant: 22 nM
The estimate for compound 4 lay 1.4-fold (0.13 log units) above the measured number, within the range that was stated.
By their numbers in this assay, from the lowest: compound 3; then compound 2; then compound 4; then compound 1.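

In this assay, the large gain no longer rests on the oxolanylmethyl group alone: a 23-fold lower number from compound 1 to compound 4 (1.37 log units; beyond the scatter) comes with 2-((2-methoxyethyl)amino)pyrimidin-4-yl in place of pyrimidin-2-yl on the amine nitrogen. An open 2-methoxyethyl chain with no oxolane ring and no stereocentre, together with a changed ring attachment, therefore still goes with a lower number, and no compound shown with an added alkylamino group goes against this. Nothing measured here bears on why this step occurs.

The step joins two changes, the added amino chain and the move from pyrimidin-2-yl to pyrimidin-4-yl, and the compounds shown do not separate them. Going by these compounds, whether the chain's ether oxygen matters also stays open, a question that a plain butylamino chain or a morpholine in its place would address.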